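The source may report more compounds than this note shows. Statements on the series, on what has been measured and on what is new or still open speak of the compounds shown alone.

Measured in a functional assay on MIA PaCa-2 cells (Homo sapiens) for inhibition, read by MTT assay, with a stated time of 72 h, tested at 50 uM; a lower number here means less inhibition of growth, a higher number more inhibition of growth at the concentration tested:
Compound 1 `C=CCc1cc(O)c(O)c(CN2CCC(C)CC2)c1`: 90.6%
Compound 2 `C=CCc1cc(O)c(O)c(CN2CCC(CCO)CC2)c1`: 71.8%
Compound 3 `C=CCc1cc(O)c(O)c(CN2CCC(CO)CC2)c1`: 38.6%

Compound 3 is the lowest of the three in this assay. Compound 4 `C=CCc1cc(O)c(O)c(CN2CCC(Cc3ccccc3)CC2)c1` has phenyl in place of hydroxy on a saturated chain carbon bound to a saturated ring carbon. The measured steps bearing on this change are a number 52 percentage points lower from compound 1 to compound 3 (beyond the scatter), a large one, a number 33.2 percentage points lower from compound 2 to compound 3 (beyond the scatter), also large, and a number 18.8 percentage points lower from compound 1 to compound 2 (beyond the scatter), a modest one. Within the data shown here, no measured step brings in a phenyl, so the comparison is loose. Compound 1, which has no hydroxy on that chain, gives 90.6%, so a large rise is expected. The estimated step is a number 41.4 percentage points higher from compound 3 to compound 4 (beyond the scatter). For compound 4 the expected value is 80%, with an estimated range of 58% to 97%.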

Compound 4, percent growth inhibition at one concentration: 90.9%
Estimate against measurement, compound 4: 10.9 percentage points below, and the stated range covers the measured number.
By their numbers in this assay, from the lowest: compound 3; then compound 2; then compounds 1 and 4 (each within the scatter of the next).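

In this assay, the position takes a much larger group without loss: phenyl in place of hydrogen gives a number 0.3 percentage points higher from compound 1 to compound 4 (within the scatter). Replacing the hydroxy gives a number 52.3 percentage points higher from compound 3 to compound 4 (beyond the scatter), and replacing the hydroxymethyl gives a number 19.1 percentage points higher from compound 2 to compound 4 (beyond the scatter), so among these compounds the two without a hydroxy on that chain, compound 1 and compound 4, stand above the two that carry one. No evidence on the cause of these steps is available.

Going by these compounds, whether an amine, a carboxylic acid or a longer chain ending in phenyl would hold this level remains open. A single test concentration also leaves open whether compound 1 and compound 4 would separate at lower concentrations.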